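A few compounds are considered here, and "the series" means these few. Any claim that something is new, unique, unknown or untested is made for them only; others in the source may bear on it.

Working notes on the series. Compound 1 `Cc1ccc2c(=O)c(CSC(=S)N3CCOCC3)coc2c1` and compound 2 `COc1ccc2occ(CSC(=S)N3CCOCC3)c(=O)c2c1` carry a morpholin-4-yl group on a thiocarbonyl carbon; in a functional assay on MCF7 cells (Homo sapiens) for antiproliferative activity, read by MTT assay, with a stated time of 72 h (a higher number here means a weaker inhibitor, a lower number a stronger inhibitor), compound 1 gives 20700 nM and compound 2 gives 11800 nM. Compound 3 `CC(C)N(C(=S)SCc1coc2ccccc2c1=O)C(C)C` carries diisopropylamino on that thiocarbonyl carbon. For compound 3 this assay reports only a limit, > 30000 nM, as noted in the limit of > 30000 nM in this assay, at which 1 of the 3 values shown sits. Among the measured compounds shown here, no two measured compounds differ in a single place, so no step between measured compounds can be counted. Compound 4 `O=c1c(CSC(=S)N2CCOCC2)coc2ccccc12` is not yet measured; it differs from compound 3 by morpholin-4-yl in place of diisopropylamino on a thiocarbonyl carbon. A step toward stronger inhibition beyond the scatter is expected for compound 4, namely an at least 1.5-fold lower number from compound 3 to compound 4 (0.17 log units; that floor lies within the scatter), since compound 1 at 20700 nM and compound 2 at 11800 nM already carry the entering group. Compound 4 is estimated at 20000 nM, within 8000 nM to 40000 nM.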

Compound 4, half-maximal inhibitory concentration: 4000 nM
Compound 4: middle estimate off by 5.0-fold (0.70 log units), on the high side; measured number below the stated range.
By their numbers in this assay, from the lowest: compound 4; then compounds 2 and 1 (each within the scatter of the next). At a limit, above all of these: compound 3.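

In this assay, morpholin-4-yl in place of diisopropylamino on a thiocarbonyl carbon gives an at least 7.5-fold lower number from compound 3 to compound 4 (0.87 log units; beyond the scatter), the first step read at this position. That step rests on a limit for compound 3: the limit of > 30000 nM in this assay, at which 1 of the 4 values shown sits. Hydrogen in place of methoxy on an aromatic carbon gives a 3.0-fold lower number from compound 2 to compound 4 (0.47 log units; beyond the scatter), and hydrogen in place of methyl on an aromatic carbon gives a 5.2-fold lower number from compound 1 to compound 4 (0.71 log units; beyond the scatter), so neither substituent improves on hydrogen in these pairs.

Open, as far as these compounds go, is where piperidin-1-yl on the thiocarbonyl carbon would fall relative to morpholin-4-yl. Also open, from the compounds shown here alone, is how a chloro group on an aromatic carbon compares with hydrogen.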